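The source may hold more compounds than are shown below. What is called first, only, known or untested is meant among the compounds shown, and "the series" means these compounds.

In a functional assay (aorta) with Rattus norvegicus as the target; a higher number here means that more compound is needed for the effect, a lower number that less compound is needed:
- compound 1 `C/N=C(/NC#N)C1=CC(C)(C)Oc2ccc(C#N)cc21`: 339 nM
- compound 2 `C/N=C(/NC#N)C1=CC(C)(C)Oc2ccc([N+](=O)[O-])cc21`: 15.1 nM
- compound 3 `CC/N=C(/NC#N)C1=CC(C)(C)Oc2ccc([N+](=O)[O-])cc21`: 89.1 nM

Compound 3 holds the middle number of the three. Compound 4 `CN(C)/C(=N\C#N)C1=CC(C)(C)Oc2ccc([N+](=O)[O-])cc21` differs from it on a double-bonded ring carbon: a group of 7 heavy atoms (4 carbon, 3 nitrogen; no ring) in place of a group of 7 heavy atoms (4 carbon, 3 nitrogen; no ring), on a double-bonded ring carbon. Among the measured compounds shown here, no measured pair shows this exact change. The closest evidence is a 5.9-fold higher number from compound 2 to compound 3 (0.77 log units; beyond the scatter), a modest step in the same group. By contrast, a 22-fold lower number from compound 1 to compound 2 (1.35 log units; beyond the scatter) is large but concerns an aromatic carbon and does not bear on this change. A further rise in this assay is therefore expected, of modest to large size. The expected step is a 9.0-fold higher number from compound 3 to compound 4 (0.95 log units; beyond the scatter). For compound 4 the estimate is 800 nM, with an expected range of 150 nM to 4500 nM.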

Compound 4, half-maximal effective concentration: < 31700 nM
Compound 4 gave a limit, no number; the forecaster's own chance of this, stated with the estimate: 10%; the middle value does not contradict the limit.
By their numbers in this assay, from the lowest: compound 2; then compound 3; then compound 1.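

In this assay, among the compounds shown here, compound 4 gives < 31700 nM, a limit and not a number, so no step from compound 2 or compound 3 to compound 4 can be read. The compounds shown leave open whether the group on the double-bonded ring carbon of compound 4 gives a higher or lower number than that of compound 3.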